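Dichlorophenyl and trichlorophenyl ozonides: one chloro removed

The compounds below may be only part of what the source reports. "The series", "measured", "known", "first", "only" and "open" are said of these compounds alone.

Compound 2 `C=C(c1ccc(Cl)c(Cl)c1Cl)C1COC(C)(C)OO1` and compound 3 `C=C(c1ccc(Cl)c(Cl)c1Cl)C1COC2(CCCCC2)OO1` carry the same trichlorinated aromatic ring on different cores; the difference between the two cores is not broken down here. In a functional assay on BEAS-2B cells (Homo sapiens) for inhibition, read by MTT assay, with a stated time of 72 h (a higher number here means a weaker inhibitor, a lower number a stronger inhibitor), compound 2 gives 10200 nM. In the same assay compound 3 gives 10300 nM, a value within the scatter of compound 2. Compound 1 `C=C(c1ccc(Cl)c(Cl)c1)C1COC(C)(C)OO1` lacks one chloro relative to compound 2. In this assay compound 1 reaches only a limit, > 100000 nM. The step from compound 2 to compound 1 is therefore bounded rather than fully known: an at least 9.8-fold higher number from compound 2 to compound 1 (0.99 log units; beyond the scatter). The change behind it is hydrogen in place of chloro on an aromatic carbon. The bound arises from the position of compound 1 at the limit of > 100000 nM in this assay, at which 1 of the 3 values shown sits.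

Compound 4 `C=C(c1ccc(Cl)cc1Cl)C1COC2(CCCCC2)OO1` has not been measured. It stands to compound 3 as compound 1 stands to compound 2, with the same kind of change, (hydrogen in place of chloro on an aromatic carbon), although the surroundings differ: here the hydrogen enters ortho to two chloro groups and meta to a large group, whereas in compound 1 it entered ortho to a chloro group, ortho to a large group and meta to a chloro group. On the strength of the step from compound 2 to compound 1, an at least 9.8-fold higher number from compound 2 to compound 1 (0.99 log units; beyond the scatter), compound 4 is expected to be a weaker inhibitor than compound 3, with an estimated step of a 9.7-fold higher number from compound 3 to compound 4 (0.99 log units; beyond the scatter). Compound 4 is estimated at 100000 nM in this assay, in a range from 30000 nM to 300000 nM, with a real chance that only a limit is reported.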

Compound 4, half-maximal inhibitory concentration: 16700 nM
The estimate for compound 4 lay 6.0-fold (0.78 log units) above the measured number; the measured number lies below the stated range.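

In this assay, hydrogen in place of chloro on an aromatic carbon gives a 1.6-fold higher number from compound 3 to compound 4 (0.21 log units; within the scatter), so the change does not carry over from one core to the other at the size seen earlier: the same change on two cores in this assay, an at least 9.8-fold higher number (0.99 log units; beyond the scatter) from compound 2 to compound 1 and a 1.6-fold higher number (0.21 log units; within the scatter) from compound 3 to compound 4, at least 6.0-fold (0.78 log units) apart, beyond the scatter of two such steps. The earlier step is a bound and not a full number, as compound 1 has only a limit: the limit of > 100000 nM in this assay, at which 1 of the 4 values shown sits. The two steps differ in more than the core, for the hydrogen enters ortho to two chloro groups and meta to a large group in compound 4, but ortho to a chloro group, ortho to a large group and meta to a chloro group in compound 1, so the data do not show whether the core or the place of the change separates the two steps.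

The compounds shown leave open how the step would read if the chloro left the same place on both cores. They also leave open how a fluoro, methoxy or nitrile group in place of chloro would read in this assay, since only chloro and hydrogen appear at these places on the aromatic ring.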